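A few compounds are considered here, and "the series" means these few. Any claim that something is new, unique, unknown or untested is made for them only; others in the source may bear on it.

Of the compounds shown here, three built on one shared core have been tested in a functional assay on MOLT-4 cells (Homo sapiens) for inhibition, read by sulforhodamine B assay, with a stated time of 48 h; a lower number here means a stronger inhibitor of growth, a higher number a weaker inhibitor of growth. Compound 1 `O=C(Nc1cccc(-n2cc(-c3ccncc3)c(-c3ccc(Cl)c(O)c3)n2)c1)Nc1cccc(C(F)(F)F)c1` gives 1920 nM. Compound 2 `COc1cc(-c2nn(-c3cccc(NC(=O)Nc4cc(C(F)(F)F)cc(C(F)(F)F)c4)c3)cc2-c2ccncc2)ccc1Cl` gives 1080 nM, and compound 3 `COc1cc(-c2nn(-c3cccc(NC(=O)Nc4cccc(C(F)(F)F)c4)c3)cc2-c2ccncc2)ccc1Cl` gives 936 nM. For the measured compounds named here, of these three numbers the one for compound 2 is the middle one, yet its gaps to compound 3 and to compound 1 both lie within the usual scatter, so no real difference among the three can be read from them.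

Compound 4 `O=C(Nc1cccc(-n2cc(-c3ccncc3)c(-c3ccc(Cl)c(O)c3)n2)c1)Nc1cc(C(F)(F)F)cc(C(F)(F)F)c1` has not yet been measured. It differs from compound 2 in a single place: hydrogen in place of methyl on an oxygen on an aromatic ring. One measured step speaks directly to this change, run the other way round: a 2.1-fold lower number from compound 1 to compound 3 (0.31 log units; beyond the scatter). The other step, a 1.2-fold lower number from compound 2 to compound 3 (0.06 log units; within the scatter), concerns a different position and does not bear on it. Turning the first step around suggests that hydrogen in place of methyl should push the number up by a modest amount, just beyond the scatter. On that basis compound 4 is expected to give about 2200 nM in this assay, with a likely range from 1200 nM to 4500 nM. This estimate means a step of a 2.0-fold higher number from compound 2 to compound 4 (0.31 log units; beyond the scatter), a modestly weaker inhibitor of growth than compound 2.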

Compound 4, concentration for 50% growth inhibition: 1150 nM
The estimate for compound 4 lay 1.9-fold (0.28 log units) above the measured number, outside the stated range (below it).
By their numbers in this assay, from the lowest: compounds 3, 2, 4 and 1 (each within the scatter of the next, the first and the last beyond it).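

In this assay, replacing methoxy with hydroxy on the compounds carrying two trifluoromethyl groups gives a 1.1-fold higher number from compound 2 to compound 4 (0.03 log units; within the scatter), so on this core the change has no readable effect. The earlier step, just beyond the scatter, therefore cannot be taken as a general rule for this position, and it does not show that the effect depends on the core either, as the two readings of the same change are close enough to be one effect seen through ordinary scatter: the same change on two cores in this assay, a 2.1-fold lower number (0.31 log units; beyond the scatter) from compound 1 to compound 3 and a 1.1-fold lower number (0.03 log units; within the scatter) from compound 4 to compound 2, 1.9-fold (0.28 log units) apart, within the scatter of two such steps. The second trifluoromethyl group, compared on the hydroxy compounds, gives a 1.7-fold lower number from compound 1 to compound 4 (0.22 log units; within the scatter), which also stays within the scatter and fits what the methoxy pair showed: the same change on two cores in this assay, a 1.2-fold lower number (0.06 log units; within the scatter) from compound 2 to compound 3 and a 1.7-fold higher number (0.22 log units; within the scatter) from compound 4 to compound 1, 1.9-fold (0.28 log units) apart, within the scatter of two such steps.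

On these data alone, the four compounds carry only methoxy or hydroxy at this place on the 4-chloro phenyl ring, so what a longer chain such as ethoxy or an amine would do there remains open. Also open, as far as these compounds go, is whether any replacement at this place can move growth inhibition clearly beyond the scatter, since the steps seen so far are all small.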